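This account rests on a few compounds, and the source may have more. Where it says the series, first, only, none or still open, it means among the compounds named here.

Compound 1 `COc1ccc(C(=O)NCc2ccc(CNS(=O)(=O)c3ccccc3)cc2)cc1` has the highest of the three numbers in an assay on MDA-MB-231 cells for binding affinity to C-X-C chemokine receptor type 4 (Homo sapiens), read by immunofluorescence and microscopy, with stated times of 10 min and 30 min (a higher number here means that more compound is needed for the effect, a lower number that less compound is needed), giving 1000 nM. Compound 2 `COc1ccc(C(=O)NCc2ccc(CNS(=O)(=O)c3ccc(C)cc3)cc2)cc1` gives 100 nM, and compound 3 `Cc1ccc(S(=O)(=O)NCc2ccc(CNC(=O)c3ccc(Cl)cc3)cc2)cc1` gives 10 nM. The two measured steps are a 10-fold lower number from compound 1 to compound 2 (1.00 log units; beyond the scatter), methyl in place of hydrogen on an aromatic carbon, and a 10-fold lower number from compound 2 to compound 3 (1.00 log units; beyond the scatter), chloro in place of methoxy on an aromatic carbon.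

Compound 4 `O=C(NCc1ccc(CNS(=O)(=O)c2ccccc2)cc1)c1c(Cl)cc(Cl)cc1Cl` is not yet measured in this assay. Its change from compound 1 is 2,4,6-trichlorophenyl in place of 4-methoxyphenyl on a carbonyl carbon. Of the measured steps, only a 10-fold lower number from compound 2 to compound 3 (1.00 log units; beyond the scatter) bears on it directly, that step likewise having put chloro in place of methoxy on an aromatic carbon. Among the compounds with values here, compound 4 lacks the methyl that compound 2 carries, so the step from compound 1 to compound 2 does not apply, and the two additional chloro groups of the 2,4,6-trichlorophenyl have no measured counterpart. Within the data shown here, a lower number than compound 1 is therefore expected, though a more modest one than the single chloro exchange gave. Compound 4 is estimated at 300 nM, range 50 nM to 2000 nM, which would be a step of a 3.3-fold lower number from compound 1 to compound 4 (0.52 log units; beyond the scatter).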

Compound 4, effective concentration (reported as EC, without a stated level of effect): 10 nM
Beside the measured number, compound 4's estimate is 30-fold (1.48 log units) above it, and the stated range ends above it.
By their numbers in this assay, from the lowest: compounds 3 and 4 (each within the scatter of the next); then compound 2; then compound 1.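

Within the data shown here, the carbonyl-bearing aryl position tolerates a much heavier chloro substitution than the earlier compounds showed: a 100-fold lower number from compound 1 to compound 4 (2.00 log units; beyond the scatter) in this assay, with the phenyl on the sulfonyl side left unsubstituted. This step is larger than a 10-fold lower number from compound 2 to compound 3 (1.00 log units; beyond the scatter), although that one was read with the methyl present, so the two changes at this position share a direction but not a background. No measurement at hand accounts for the size of the step.

Still open, going by these compounds, is how the step divides among the three chloro groups of the 2,4,6-trichlorophenyl, and whether the methyl of compound 2 would lower the number further with that group in place. Also open, on these data alone, is how an amine or a carboxylic acid on this ring would read.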